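Swapping the sulfonyl for a phosphate chain on the amide

The source may report more compounds than this note shows. Statements on the series, on what has been measured and on what is new or still open speak of the compounds shown alone.

Measured so far:
compound 1 `CC(C)c1onc(-c2c(Cl)cccc2Cl)c1COc1ccc(N(C)Cc2cccc(C(=O)O)c2)c(C(F)(F)F)n1` gives 12 nM
compound 2 `CC(C)c1onc(-c2c(Cl)cccc2Cl)c1COc1ccc(N(C)Cc2cccc(C(=O)NS(C)(=O)=O)c2)c(C(F)(F)F)n1` gives 48 nM

Both compounds were tested in an assay on isolated protein for agonist activity at Bile acid receptor (Homo sapiens), read by FRET; a higher number here means that more compound is needed for the effect, a lower number that less compound is needed. Of the two numbers, compound 2 stands at the higher one: compared with compound 1 the change was a 4.0-fold higher number from compound 1 to compound 2 (0.60 log units; beyond the scatter), where the acid was replaced by an acylsulfonamide. Compound 3 `CC(C)c1onc(-c2c(Cl)cccc2Cl)c1COc1ccc(N(C)Cc2cccc(C(=O)NCCOP(=O)(O)O)c2)c(C(F)(F)F)n1` goes one step further at the same place: a group of 7 heavy atoms (2 carbon, 4 oxygen, 1 phosphorus; no ring) in place of a group of 4 heavy atoms (1 carbon, 2 oxygen, 1 sulfur; no ring), on an amide-type nitrogen. For the measured compounds named here, only one measured step touches this region, the change from compound 1 to compound 2, and it moved the number by a modest amount. Going by the values given here, no step in the data shows what a chain carrying a phosphorus group does at this position, so the direction is uncertain. The expectation for compound 3 is therefore a change of a 1.7-fold higher number from compound 2 to compound 3 (0.22 log units; within the scatter) in this assay, with a wide range. The estimated value for compound 3 is 80 nM, between 25 nM and 300 nM.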

Compound 3, half-maximal effective concentration: 36 nM
Compound 3: the middle estimate sits 2.2-fold (0.35 log units) above what was measured; measured number inside the range.
By their numbers in this assay, from the lowest: compound 1; then compounds 3 and 2 (each within the scatter of the next).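

In this assay the larger group on the amide-type nitrogen gives a 1.3-fold lower number from compound 2 to compound 3 (0.12 log units; within the scatter) and so cannot be told apart from the methylsulfonyl group. Set against the carboxylic acid, the same chain gives a 3.0-fold higher number from compound 1 to compound 3 (0.48 log units; beyond the scatter) and leaves compound 1 with the lowest number of the three, by a modest margin. This position therefore takes a group of 7 heavy atoms with a phosphorus in it, in place of a group of 4 heavy atoms, with no change that can be read beyond the scatter.

No measurement in hand explains why these numbers fall as they do. Open too, from the compounds shown here alone, is how a plain methyl group, a longer chain, or an amine at the end of the chain would behave on this nitrogen.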